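Morpholin-4-yl in place of methyl(propyl)amino: a stability estimate

The source may hold more compounds than are shown below. What is called first, only, known or untested is meant among the compounds shown, and "the series" means these compounds.

Compound 1 `CCOc1cc(NC(=O)C2(NC(=O)c3ccc4c(C5CCCC5)c(-c5ncc(Cl)cn5)n(C)c4c3)CCC2)ccc1/C=C/C(=O)OCOP(=O)(O)OC(C)(C)C`: 1.48 h
Compound 2 `CCOC(=O)/C=C/c1ccc(NC(=O)C2(NC(=O)c3ccc4c(C5CCCC5)c(-c5ncc(Cl)cn5)n(C)c4c3)CCC2)cc1OCC`: a limit, > 5 h
Compound 3 `CCCN(C)C(=O)COC(=O)/C=C/c1ccc(NC(=O)C2(NC(=O)c3ccc4c(C5CCCC5)c(-c5ncc(Cl)cn5)n(C)c4c3)CCC2)cc1OCC`: 0.317 h

In an ADME assay (liver) for pharmacokinetics, with Liver microsome (Homo sapiens) as the target, using microsomes (a lower number here means that the compound disappears faster, a higher number that the compound lasts longer), compound 3 holds the lowest of the two numbers; its nearest neighbour is compound 1, through the step of a 4.7-fold lower number from compound 1 to compound 3 (0.67 log units; beyond the scatter). Compound 4 `CCOc1cc(NC(=O)C2(NC(=O)c3ccc4c(C5CCCC5)c(-c5ncc(Cl)cn5)n(C)c4c3)CCC2)ccc1/C=C/C(=O)OCC(=O)N1CCOCC1` carries the change (morpholin-4-yl in place of methyl(propyl)amino on a carbonyl carbon). Every measured step alters the group on a saturated chain carbon bound to an oxygen next to a carbonyl group, the largest being an at least 15-fold lower number from compound 2 to compound 3 (1.19 log units; beyond the scatter), while the step of an at least 3.3-fold higher number from compound 1 to compound 2 (0.52 log units; beyond the scatter) is smaller. None of them varies the amine on the carbonyl, so the step of a 1.1-fold higher number from compound 3 to compound 4 (0.04 log units; within the scatter) is expected to stay small, without a clear direction. Compound 4 is therefore estimated at 0.35 h, within 0.15 h to 0.9 h.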

Compound 4, half-life: 0.667 h
Compound 4: middle estimate off by 1.9-fold (0.28 log units), on the low side, within the range that was stated.
By their numbers in this assay, from the lowest: compound 3; then compound 4; then compound 1. At a limit, above all of these: compound 2.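

In this assay, going by these compounds alone, the amine on the carbonyl carbon does count: the step of a 2.1-fold higher number from compound 3 to compound 4 (0.32 log units; beyond the scatter) comes with morpholin-4-yl in place of methyl(propyl)amino, a change no earlier step varied. The new group still falls short of the other two groups on the saturated chain carbon, with a 2.2-fold lower number from compound 1 to compound 4 (0.35 log units; beyond the scatter) and an at least 7.4-fold lower number from compound 2 to compound 4 (0.87 log units; beyond the scatter) as the steps. The second of these is only a bound, since the value of compound 2 is a limit: the limit of > 5 h in this assay, at which 1 of the 4 values shown sits.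

The compounds shown cannot separate the ring from its oxygen. Piperidin-1-yl or dimethylamino on the same carbonyl carbon would bear on that.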